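Urea aryl swap on a pyrazole scaffold: expected activity

This account rests on a few compounds, and the source may have more. Where it says the series, first, only, none or still open, it means among the compounds named here.

Compound 2 `COc1cc(Cl)cc(-c2nn(-c3cccc(NC(=O)Nc4ccc(Cl)c(Cl)c4)c3)cc2-c2ccncc2)c1` belongs to a pair of ureas sharing one core. In a functional assay on HCT-15 cells (Homo sapiens) for inhibition, read by sulforhodamine B assay, with a stated time of 48 h, tested at 0.01 uM (on this read-out lower numbers stand for a stronger effect and higher numbers for a weaker effect at the one concentration tested), compound 2 gives 93%. Its companion, compound 1 `COc1cc(Cl)cc(-c2nn(-c3cccc(NC(=O)Nc4ccc(Cl)c(C(F)(F)F)c4)c3)cc2-c2ccncc2)c1`, gives 92% in this assay. For the measured compounds named here, the two numbers sit within the scatter of each other, as the single measured step shows: a number 1 percentage points higher from compound 1 to compound 2 (within the scatter) went with chloro in place of trifluoromethyl on an aromatic carbon.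

Compound 3 `COc1cc(Cl)cc(-c2nn(-c3cccc(NC(=O)Nc4cccc(C(F)(F)F)c4)c3)cc2-c2ccncc2)c1` is not yet measured in this assay. It differs from compound 2 in one place: 3-(trifluoromethyl)phenyl in place of 3,4-dichlorophenyl on an amide-type nitrogen. Going by the values given here, the only measured step bears on this change in part, since it also exchanged chloro and trifluoromethyl on the same ring, and it was small, within the scatter. Nothing measured here tells what the loss of one chlorine does. Given that, the expected step in this assay, a number 1 percentage points higher from compound 2 to compound 3 (within the scatter), is none beyond the scatter. Compound 3 is therefore estimated to give about 94% in this assay, with a range from 84% to 100%.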

Compound 3, a percentage reported as activity, at one concentration (the size of the read-out at that concentration, not a potency): 92%
For compound 3 the middle estimate is 2 percentage points above the measured one; the measured number falls inside the stated range.
By their numbers in this assay, from the lowest: compounds 1, 3 and 2 (each within the scatter of the next).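

In this assay, the swap of 3,4-dichlorophenyl for 3-(trifluoromethyl)phenyl on an amide-type nitrogen goes with a number 1 percentage points lower from compound 2 to compound 3 (within the scatter), so an exchange that alters the whole substitution of this ring still does not move the read-out beyond the scatter. The earlier pair said nothing about the loss of a chlorine, and this result fills that gap: hydrogen in place of chloro on an aromatic carbon goes with no change at the digits printed from compound 1 to compound 3 (within the scatter). The three aryl groups on this urea nitrogen therefore cannot be told apart at the one concentration tested, and nothing given here offers an explanation for that.

Going by these compounds, it remains open whether a different kind of group on this ring, such as an amine, a carboxylic acid or a methoxy group, would shift the number beyond the scatter. On these data alone, it is also open whether these three ureas, which read alike at this single concentration, would separate from one another at higher concentrations.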